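Adding an Ethyl Group to the Most Potent Chain Length

The source may report more compounds than this note shows. Statements on the series, on what has been measured and on what is new or still open speak of the compounds shown alone.

Three compounds share one core and differ in the length of their carbon chain. In a functional assay on Huh-7 cells (Homo sapiens) for inhibition, read by CCK-8 assay, with a stated time of 72 h (a higher number here means a weaker inhibitor, a lower number a stronger inhibitor), compound 1 (`O=C(/C=C/c1cccnc1)NCCCc1cccc(S(=O)(=O)Nc2ccccc2)c1`), with the shortest chain, gives 384 nM. Compound 3 (`O=C(/C=C/c1cccnc1)NCCCCCCCc1cccc(S(=O)(=O)Nc2ccccc2)c1`), with the longest chain, gives 138 nM. Compound 2 (`O=C(/C=C/c1cccnc1)NCCCCCCc1cccc(S(=O)(=O)Nc2ccccc2)c1`), with a chain of intermediate length, gives 2.82 nM. This is the lowest number of the three, and its gaps to the other two lie well beyond the usual scatter of repeated measurements, so compound 2 is the strongest inhibitor here.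

Compound 4 (`CCc1ccc(NS(=O)(=O)c2cccc(CCCCCCNC(=O)/C=C/c3cccnc3)c2)cc1`) keeps the chain of compound 2 and changes one spot: ethyl in place of hydrogen on an aromatic carbon. This places ethyl in place of hydrogen on an aromatic carbon. Going by the values given here, no measured pair tests a change at this spot, so the chain comparisons offer only indirect guidance. In this assay, the estimated step of a 2.8-fold higher number from compound 2 to compound 4 (0.45 log units; beyond the scatter) is a modest one towards weaker inhibition, and it may not exceed the scatter. For compound 4, the expected value is 8 nM, with an estimated range from 1.5 nM to 50 nM.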

Compound 4, half-maximal inhibitory concentration: 34.6 nM
Estimate against measurement, compound 4: 4.3-fold (0.64 log units) below; the range from low to high includes it.
By their numbers in this assay, from the lowest: compound 2; then compound 4; then compound 3; then compound 1.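

The earlier compounds shown here differed only in chain length, so they said nothing about the aromatic ring at the other end of the molecule. In this assay, going from phenyl to 4-ethylphenyl gives a 12-fold higher number from compound 2 to compound 4 (1.09 log units; beyond the scatter), a large step towards weaker inhibition. This position is therefore sensitive to change: an ethyl group of just 2 heavy atoms, placed para to a large group, moves the number well beyond the scatter. Nothing measured here gives a reason for this loss.

Going by these compounds, it remains open whether a methyl group, a fluorine atom or an amine at this same place would weaken inhibition less, or not at all. On these data alone, it also remains open whether the ethyl group would give a step of similar size on the shorter or longer chains of compound 1 and compound 3.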